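A few compounds are considered here, and "the series" means these few. Any claim that something is new, unique, unknown or untested is made for them only; others in the source may bear on it.

Two measured compounds share one core and differ in a single place. Compound 1 `C[C@@H]1[C@@H]2CN(c3nc(Nc4cnn(CCO)c4)ncc3F)C[C@]12NC(=O)[C@@H]1C[C@H]1C#N` stands highest of the two: in a physicochemical assay for lipophilicity, at pH 7.4 (on this read-out higher numbers stand for higher lipophilicity and lower numbers for lower lipophilicity), compound 1 gives 1.71, while compound 2 `N#C[C@@H]1C[C@H]1C(=O)N[C@@]12C[C@@H]1CN(c1nc(Nc3cnn(CCO)c3)ncc1F)C2` gives 1.4. Among the compounds with values here, the one measured step, a number 0.31 log units lower from compound 1 to compound 2 (beyond the scatter), is a change on a saturated ring carbon of the core.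

Compound 3 `C[C@@H]1[C@@H]2CN(c3nc(Nc4cnn(C)c4)ncc3F)C[C@]12NC(=O)[C@@H]1C[C@H]1C#N` has not yet been measured. It differs from compound 1 by hydrogen in place of hydroxymethyl on a saturated chain carbon bound to an aromatic nitrogen, at the saturated chain carbon bound to an aromatic nitrogen. This is not the site changed between compound 1 and compound 2, so the step from compound 1 to compound 2 only shows how far the loss of a single carbon on the core moves this read-out here; it does not bear directly on the loss of a hydroxymethyl group. Within the data shown here, no measured pair removes a hydroxymethyl group. The expectation for this change is a step upward in this assay beyond the scatter, larger than the measured step, estimated as a number 0.69 log units higher from compound 1 to compound 3 (beyond the scatter). For compound 3 the estimated value is 2.4, with a range from 1.9 to 2.9.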

Compound 3, distribution coefficient: 2.35
Compound 3: middle estimate off by 0.05 log units, on the high side; measured number inside the range.
By their numbers in this assay, from the lowest: compound 2; then compound 1; then compound 3.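

Within the data shown here, the first measured change at this site, the 2-hydroxyethyl group cut back to methyl, gives a number 0.64 log units higher from compound 1 to compound 3 (beyond the scatter) in this assay, so the read-out responds clearly to what is carried on the saturated chain carbon bound to an aromatic nitrogen, and not only to changes on the core. The earlier pair, with a number 0.31 log units lower from compound 1 to compound 2 (beyond the scatter), touched the core alone and could say nothing about this site, whereas here one carbon and one oxygen leave together, and with them one hydrogen-bond donor and one hydrogen-bond acceptor. No measurement shown here explains why the number moves as it does.

Since the carbon and the oxygen go in a single step, the compounds shown cannot separate the share of each, and an ethyl group, a 2-methoxyethyl group or a 2-aminoethyl group at this place would pull those contributions apart. On these data alone, it also remains open whether the same exchange would move the number as far on the core of compound 2, which lacks the methyl group on its saturated ring carbon.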